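Removing One Trifluoromethyl From a Urea Tail

The source may hold more compounds than are shown below. What is called first, only, known or untested is meant among the compounds shown, and "the series" means these compounds.

Of the compounds shown here, two have so far been measured in a functional assay on OVCAR-8 cells (Homo sapiens) for inhibition, read by sulforhodamine B assay, with a stated time of 48 h; on this read-out lower numbers stand for stronger inhibition of growth and higher numbers for weaker inhibition of growth. Compound 1 `COc1cc(-c2nn(-c3cccc(NC(=O)c4ccc(Cl)c(C(F)(F)F)c4)c3)cc2-c2ccncc2)ccc1Cl` gives 3350 nM in this assay. Compound 2 `O=C(Nc1cccc(-n2cc(-c3ccncc3)c(-c3ccc(Cl)c(O)c3)n2)c1)Nc1cc(C(F)(F)F)cc(C(F)(F)F)c1` gives 563 nM, the lower of the two numbers; these two compounds differ in several places, so only their values stand side by side. Compound 3 `O=C(Nc1cccc(-n2cc(-c3ccncc3)c(-c3ccc(Cl)c(O)c3)n2)c1)Nc1cccc(C(F)(F)F)c1` keeps the core of compound 2 and differs from it by hydrogen in place of trifluoromethyl on an aromatic carbon. For the measured compounds named here, no measured pair shows this change. A modest weakening is expected, about a 1.6-fold higher number from compound 2 to compound 3 (0.20 log units; within the scatter), within or just beyond the usual scatter. Compound 3 is therefore estimated at 900 nM, with a range from 350 nM to 2500 nM.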

Compound 3, concentration for 50% growth inhibition: 1570 nM
Compound 3: the middle estimate sits 1.7-fold (0.24 log units) below what was measured; the measured number falls inside the stated range.
By their numbers in this assay, from the lowest: compound 2; then compound 3; then compound 1.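

In this assay, replacing trifluoromethyl with hydrogen on this aromatic carbon gives a 2.8-fold higher number from compound 2 to compound 3 (0.45 log units; beyond the scatter) and provides the first single-change comparison among these compounds. Thus, with the core and the other trifluoromethyl group unchanged, this substituent makes a measurable difference to growth inhibition. No measurement shown explains the shift.

The compounds shown leave open whether another group at this carbon, such as methyl or an amine, would match trifluoromethyl or fall closer to hydrogen. They also leave open what removing the remaining trifluoromethyl group would do.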